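Adding benzyloxy to compound 3

The source may report more compounds than this note shows. Statements on the series, on what has been measured and on what is new or still open speak of the compounds shown alone.

Values in a functional assay on U-87MG ATCC cells for inhibition, with U-87 MG (Homo sapiens) as the target, read by MTT assay, with a stated time of 72 h (a lower number here means a stronger inhibitor, a higher number a weaker inhibitor), for the measured compounds:
- compound 1 `Cc1ccnc(NC(c2ccc(C(F)(F)F)cc2)c2ccc3cccnc3c2O)c1` gives 2100 nM here
- compound 2 `Cc1ccnc(NC(c2ccccc2F)c2ccc3cccnc3c2O)c1` gives 13100 nM here
- compound 3 `Cc1ccnc(NC(c2ccccc2)c2ccc3cccnc3c2O)c1` gives > 10000 nM as a limit

Compound 3 has only a limit and no number. Compound 4 `Cc1ccnc(NC(c2ccc(OCc3ccccc3)cc2)c2ccc3cccnc3c2O)c1` differs from it by benzyloxy in place of hydrogen on an aromatic carbon with benzyloxy in place of hydrogen on an aromatic carbon, para to a large group. The closest measured change is an at least 4.7-fold higher number from compound 1 to compound 3 (0.67 log units; beyond the scatter) with hydrogen in place of trifluoromethyl. Also relevant is a 6.2-fold higher number from compound 1 to compound 2 (0.80 log units; beyond the scatter) for a change of the same aromatic group. The fluoro step, a step that the limit leaves unreadable from compound 2 to compound 3, gives no size. Read in reverse, these suggest a modest fall in the number, although benzyloxy itself is untested in this series. An estimated step of an at least 3.3-fold lower number from compound 3 to compound 4 (0.52 log units; beyond the scatter) is expected in this assay on this basis. Compound 4 is estimated at 3000 nM (expected range 800 nM to 12000 nM).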

Compound 4, half-maximal inhibitory concentration: 9300 nM
The estimate for compound 4 lay 3.1-fold (0.49 log units) below the measured number, within the range that was stated.
By their numbers in this assay, from the lowest: compound 1; then compounds 4 and 2 (each within the scatter of the next).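

In this assay, the aromatic carbon para to a large group tolerates benzyloxy with a measurable value, but this group does not match trifluoromethyl there, with a 4.4-fold higher number from compound 1 to compound 4 (0.65 log units; beyond the scatter). Relative to hydrogen, any change cannot be sized, with an at least 1.0-fold lower number from compound 3 to compound 4 (0.03 log units; that floor lies within the scatter). Compound 3 carries a limit and not a number: the limit of > 10000 nM in this assay, at which 1 of the 4 values shown sits.

As far as these compounds go, whether the benzyl ring of benzyloxy matters, or only the ether oxygen, stays open, and methoxy would separate the two. Also open, from the compounds shown here alone, is how an amine or a carboxylic acid at this carbon would compare with trifluoromethyl.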